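Working notes: ring-free sulfur group replacing cyclopropylcarbamoyl

A few compounds are considered here, and "the series" means these few. Any claim that something is new, unique, unknown or untested is made for them only; others in the source may bear on it.

Measured so far in an assay on DDT1 cells (Cricetulus griseus) for binding affinity to adenosine receptor A1 (Homo sapiens), read by radioligand binding; a higher number here means a weaker inhibitor, a lower number a stronger inhibitor:
Compound 1, `C/N=C(\S)OC[C@H]1OC(n2cnc3c(NC4CCOC4)ncnc32)[C@H](O)[C@@H]1O`, gives 45 nM.
Compound 2, `O=C(NC1CC1)OC[C@H]1OC(n2cnc3c(NC4CCOC4)ncnc32)[C@H](O)[C@@H]1O`, gives 209 nM.
Compound 3, `O=C(NC1CCC1)OC[C@H]1OC(n2cnc3c(NC4CCOC4)ncnc32)[C@H](O)[C@@H]1O`, gives 306 nM.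

Compound 2 stands second highest of the three numbers; its nearest neighbour is compound 3, at a 1.5-fold higher number from compound 2 to compound 3 (0.17 log units; within the scatter), and its furthest is compound 1, the step being a 4.6-fold higher number from compound 1 to compound 2 (0.67 log units; beyond the scatter). Compound 4, `CN(C)C(=S)OC[C@H]1OC(n2cnc3c(NC4CCOC4)ncnc32)[C@H](O)[C@@H]1O`, is not yet measured. The change from compound 2 is a group of 5 heavy atoms (3 carbon, 1 nitrogen, 1 sulfur; no ring) in place of a group of 6 heavy atoms (4 carbon, 1 nitrogen, 1 oxygen; one three-membered non-aromatic ring of carbon only), on an oxygen on a saturated carbon. The group that enters is sulfur-bearing and ring-free, which is also what the group on compound 1 is, so the relevant measured steps are those leading away from compound 1: a 4.6-fold higher number from compound 1 to compound 2 (0.67 log units; beyond the scatter) and a 6.8-fold higher number from compound 1 to compound 3 (0.83 log units; beyond the scatter), both modest and beyond the scatter. Running that direction back from compound 2, a modest lowering of the number in this assay is expected for compound 4, roughly a 2.6-fold lower number from compound 2 to compound 4 (0.42 log units; beyond the scatter). The estimate for compound 4 is therefore 80 nM, with a range from 35 nM to 200 nM.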

Compound 4, inhibition constant: 205 nM
Compound 4: middle estimate off by 2.6-fold (0.41 log units), on the low side, and the stated range ends below it.
By their numbers in this assay, from the lowest: compound 1; then compounds 4, 2 and 3 (each within the scatter of the next).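

In this assay, a sulfur-bearing, ring-free group on this oxygen does not by itself give a lower number: the group in compound 4 cannot be told apart from cyclopropylcarbamoyl (a 1.0-fold lower number from compound 2 to compound 4 (0.01 log units; within the scatter)) or from the cyclobutyl analogue (a 1.5-fold lower number from compound 3 to compound 4 (0.17 log units; within the scatter)). The low number of compound 1 therefore belongs to its particular group and not to sulfur or the absence of a ring in general, since the step between these two sulfur-bearing groups lies beyond the scatter (a 4.6-fold higher number from compound 1 to compound 4 (0.66 log units; beyond the scatter)). No measurement shown here accounts for that gap.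

As far as these compounds go, whether the low number of compound 1 survives a change of its group, such as an ethyl in place of its methyl on nitrogen, remains open. So does the standing of a plain acetyl on this oxygen among compounds 1 to 4.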